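This account rests on a few compounds, and the source may have more. Where it says the series, first, only, none or still open, it means among the compounds named here.

Measured so far:
- compound 1, `CCCCCOC(=O)N1CCN(C(=O)[C@H](CCC(=O)O)NC(=O)c2cc(N3CCC(OCCO)CC3)nc(-c3ccccc3)n2)CC1`: 0.8 L/kg in an in vivo ADME assay on the whole organism (strain Sprague-Dawley) for pharmacokinetics, with Rattus norvegicus as the target; on this read-out lower numbers stand for narrower distribution and higher numbers for wider distribution into tissues
- compound 2, `CCCCCOC(=O)N1CCN(C(=O)[C@H](CCC(=O)O)NC(=O)c2nc(-c3ccccc3)cc(N3CCC(COC)CC3)n2)CC1`: 0.15 L/kg in this assay

Compound 1 stands at the higher of the two numbers in this assay. Its nearest neighbour is compound 2, whose number lies a good way lower, a gap beyond the scatter. Among the compounds with values here, no step between measured compounds that differ in one place is known here, so the spread between compound 1 and compound 2 only shows how far numbers of this kind can move.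

The step under consideration leads from compound 1 to compound 3, `CCCCCOC(=O)N1CCN(C(=O)[C@H](CCC(=O)O)NC(=O)c2cc(N3CCC(CNC)CC3)nc(-c3ccccc3)n2)CC1`. The structural change is (methylamino)methyl in place of 2-hydroxyethoxy on a saturated ring carbon. Within the data shown here, no measured step speaks to this change, so any expectation rests on the value of compound 1 alone.

For compound 3 in this assay the expected result is 1.2 L/kg, with a range from 0.4 L/kg to 3.5 L/kg. The step of a 1.5-fold higher number from compound 1 to compound 3 (0.18 log units; within the scatter) is estimated as a modest widening, close to the edge of the scatter.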

Compound 3, volume of distribution at steady state: 2 L/kg
The estimate for compound 3 lay 1.7-fold (0.22 log units) below the measured number, and the stated range covers the measured number.
By their numbers in this assay, from the lowest: compound 2; then compound 1; then compound 3.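

Set in this assay, (methylamino)methyl in place of 2-hydroxyethoxy on a saturated ring carbon gives a 2.5-fold higher number from compound 1 to compound 3 (0.40 log units; beyond the scatter), a modest step that lies beyond the scatter. Within the data shown here, the earlier compounds offered no step confined to one place, so this is the first sign that a change at this ring carbon alone, with the core of compound 1 kept, can move the read-out, here towards wider distribution into tissues. No measurement at hand bears on what lies behind the step, and the two compounds alone cannot separate the loss of the 2-hydroxyethoxy group from the arrival of the (methylamino)methyl group.

As far as these compounds go, it remains open whether the amine nitrogen or the length and makeup of the chain carries the step, a question that aminomethyl, dimethylaminomethyl or hydroxymethyl on the same ring carbon would address, while a carboxylic acid there would test a quite different kind of group. From the compounds shown here alone, it also remains open whether the same exchange would give a step of similar size on the core of compound 2.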